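A few compounds are considered here, and "the series" means these few. Any claim that something is new, unique, unknown or untested is made for them only; others in the source may bear on it.

Measured so far:
Compound 1 `CNC(=O)C[C@@H]1C[C@@H](c2ccc(Cl)c(Cl)c2)[C@H](NC(=O)c2cc(-c3c(Cl)cnn3C)c(Cl)o2)CN1`: 40 nM
Compound 2 `Cn1ncc(Cl)c1-c1cc(C(=O)N[C@@H]2CN[C@H](CCO)C[C@H]2c2ccc(F)c(F)c2)oc1Cl`: 60 nM

Both compounds were tested in a functional assay on LNCaP cells (Homo sapiens) for antiproliferative activity; on this read-out higher numbers stand for weaker inhibition and lower numbers for stronger inhibition. There, compound 1 gives 40 nM and compound 2 gives 60 nM. For the measured compounds named here, these two numbers lie within the usual scatter of repeated measurements, so compound 1 stands level with the only other measured compound, and neither can be ranked above the other.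

The next compound to be tested is compound 3 `Cn1ncc(Cl)c1-c1cc(C(=O)N[C@@H]2CN[C@H](CC(N)=O)C[C@H]2c2ccc(Cl)c(Cl)c2)oc1Cl`. It keeps the core of compound 1 and changes one small detail: hydrogen in place of methyl on an amide-type nitrogen. In words, hydrogen takes the place of methyl on an amide-type nitrogen, so methylcarbamoyl becomes carbamoyl, and the (methylcarbamoyl)methyl group becomes carbamoylmethyl.

Going by the values given here, no measured pair shows this change, so the data offer no direct guide to its effect, and any expectation here is a cautious one. The change is small, and the expected result in this assay is no shift beyond the scatter in either direction, with an estimated 1.1-fold higher number from compound 1 to compound 3 (0.05 log units; within the scatter). For compound 3 the estimated value is 45 nM, with an expected range from 15 nM to 130 nM.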

Compound 3, half-maximal inhibitory concentration: 160 nM
Compound 3: middle estimate off by 3.6-fold (0.55 log units), on the low side; measured number outside the range, above it.
By their numbers in this assay, from the lowest: compounds 1 and 2 (each within the scatter of the next); then compound 3.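

In this assay, taking the methyl off the amide-type nitrogen, so that (methylcarbamoyl)methyl becomes carbamoylmethyl, gives a 4.0-fold higher number from compound 1 to compound 3 (0.60 log units; beyond the scatter) and a clear loss of inhibition. This is the first pair shown that differs in only one place, and it reveals that this side chain is sensitive to a very small edit: a single carbon on that nitrogen separates two results that lie beyond the usual scatter of the measurement. The methyl therefore matters in this pair, but no separate measurement shows how it exerts its effect on these cells.

The compounds shown leave open whether the trend continues with a larger group on that nitrogen, such as ethyl or cyclopropyl, or with a second methyl, which would give a dimethylcarbamoyl group. They also leave open how a carboxylic acid in place of the amide would behave, and whether the same methyl-to-hydrogen step would have a similar size on a different version of the shared core.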